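Swapping a thioether for a fluorophenyl ether on the core

This account rests on a few compounds, and the source may have more. Where it says the series, first, only, none or still open, it means among the compounds named here.

Compound 3, with the structure `COc1ccc(Sc2nc3cc(N)cc(N)c3nc2-c2ccccc2)cc1`, is the starting point. In a functional assay on PC-3 cells (Homo sapiens) for inhibition, read by sulforhodamine B assay, with a stated time of 48 h (a higher number here means that more compound is tolerated, a lower number that less compound is tolerated), compound 3 gives 19100 nM. Compound 2, with the structure `Nc1cc(N)c2nc(-c3ccccc3)c(NCc3ccc(Cl)c(Cl)c3)nc2c1`, gives 19100 nM in this assay, which sits level with compound 3 within the scatter. Compound 1, with the structure `Nc1cc(N)c2nc(-c3ccccc3)c(Oc3ccc(Cl)c(Cl)c3)nc2c1`, has only a limit in this assay, namely < 100000 nM, so it shows no number; the limit of < 100000 nM in this assay, at which 1 of the 3 values shown sits, is what it provides.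

Compound 4, with the structure `Nc1cc(N)c2nc(-c3ccccc3)c(Oc3ccc(F)cc3)nc2c1`, differs from compound 3 by one change: 4-fluorophenoxy in place of (4-methoxyphenyl)sulfanyl on an aromatic carbon. Going by the values given here, the one measured step that touches this position, a step that the limit leaves unreadable from compound 1 to compound 3, cannot be read in size, since one end of it is the limit of compound 1. Among the compounds with values here, no measured step therefore sets a clear direction for the change from compound 3 to compound 4, and no step beyond the scatter is expected; the step of a 1.3-fold higher number from compound 3 to compound 4 (0.12 log units; within the scatter) is an estimate only. Compound 4 is expected to give about 25000 nM, with a range from 8000 nM to 80000 nM.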

Compound 4, concentration lethal to 50% of the cells: 83200 nM
Beside the measured number, compound 4's estimate is 3.3-fold (0.52 log units) below it, and the stated range ends below it.
By their numbers in this assay, from the lowest: compounds 2 and 3 (each within the scatter of the next); then compound 4.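

In this assay, this position now has its first readable step: 4-fluorophenoxy in place of (4-methoxyphenyl)sulfanyl gives a 4.4-fold higher number from compound 3 to compound 4 (0.64 log units; beyond the scatter). The group on this aromatic carbon, next to the ring nitrogen, can therefore shift the number beyond the usual scatter, with more compound tolerated after this change. The steps from compound 1 still cannot be read, since compound 1 has only a limit: the limit of < 100000 nM in this assay, at which 1 of the 4 values shown sits.

This one step changes the linking sulfur to oxygen and the methoxy group to fluorine together, so the compounds shown cannot say how much of the shift belongs to each. Also open, as far as these compounds go, is how a nitrile or a carboxylic acid in place of that fluorine would behave on the phenoxy ring of compound 4.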